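The compounds below may be only part of what the source reports. "The series", "measured", "known", "first", "only" and "open" are said of these compounds alone.

In an ADME assay on MT4 cells (Homo sapiens) for cytotoxicity, read by MTT assay (a lower number here means that less compound is tolerated, a higher number that more compound is tolerated), compound 3 (`Cc1ccc(N(C(=O)c2cccc(C)c2)C(=S)OCCN2C(=O)c3ccccc3C2=O)cc1`) gives only a limit, > 100000 nM. Within the data shown here, compound 2 (`Cc1ccc(N(C(=O)c2ccccc2C)C(=S)OCCN2C(=O)c3ccccc3C2=O)cc1`) also gives a limit, > 100000 nM, so the one measured step, a step that the two limits leave unreadable from compound 2 to compound 3, has no readable size. Compound 4 (`Cc1ccc(N(C(=O)c2ccc([N+](=O)[O-])cc2)C(=S)OCCN2C(=O)c3ccccc3C2=O)cc1`) carries 4-nitrophenyl in place of 3-methylphenyl on a carbonyl carbon. Compound 1 (`O=C1c2ccccc2C(=O)N1CCOC(=S)N(C(=O)c1ccc([N+](=O)[O-])cc1)c1ccc(Cl)cc1`) also has 4-nitrophenyl on a carbonyl carbon, and it too gives a limit, > 100000 nM. Among the measured compounds shown here, the whole series so far stands at the limit of > 100000 nM in this assay, at which 3 of the 3 values shown sit. No change beyond the scatter is therefore expected in this assay, and the expected step, a number no higher from compound 3 to compound 4 (the limit leaves the size open), is small. For compound 4 the estimated value is 100000 nM, with an expected range from 50000 nM to 200000 nM.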

Compound 4, half-maximal cytotoxic concentration: 58000 nM
The estimate for compound 4 lay 1.7-fold (0.24 log units) above the measured number, and the stated range covers the measured number.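

In this assay, among these compounds, compound 4 is the first compound to give a number rather than a limit: the limit of > 100000 nM in this assay, at which 3 of the 4 values shown sit. Placing 4-nitrophenyl on the carbonyl carbon gives an at least 1.7-fold lower number from compound 3 to compound 4 (0.23 log units; that floor lies within the scatter) and an at least 1.7-fold lower number from compound 2 to compound 4 (0.23 log units; that floor lies within the scatter), so neither change is shown to pass the scatter. Methyl in place of chloro on an aromatic carbon gives an at least 1.7-fold lower number from compound 1 to compound 4 (0.23 log units; that floor lies within the scatter), likewise only a floor.

On these data alone, the true size of all three steps stays open, as the limits fix floors only. The compounds shown also leave open how this assay responds to an amine or a carboxylic acid on the phenyl ring at this position.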